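The source may hold more compounds than are shown below. What is called first, only, known or untested is meant among the compounds shown, and "the series" means these compounds.

Measured in an assay on isolated protein for inhibition of DNA topoisomerase 1 (Homo sapiens), tested at 20 uM; on this read-out lower numbers stand for a weaker effect and higher numbers for a stronger effect at the one concentration tested:
Compound 1 `COc1cc(O)ccc1/C=C/C(=O)c1ccc(NC(C)=O)cc1` gives 17.3%
Compound 2 `COc1cc(O)ccc1/C=C/C(=O)c1ccc(N)cc1` gives "not determined" (no result reported); no result was reported
Compound 3 `COc1ccc(/C=C/C(=O)c2ccc(O)cc2O)cc1Br` gives 8.2%

Compound 2 therefore stands nowhere on the numbers shown: it has no single value in this assay, and only its neighbours give a sense of where this series sits. Compound 1 gives 17.3% and compound 3 gives 8.2%, both modest readings at the one concentration tested, and the gap between them is within the usual scatter of repeated measurements.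

Compound 4 `COc1cc(O)ccc1/C=C/C(=O)c1ccc(F)cc1` is not yet measured. It differs from compound 2 in one place: fluoro in place of amino on an aromatic carbon. For the measured compounds named here, no step between measured compounds covers this change, so there is nothing to say about its size from data; the expectation is that compound 4 lands near compounds 1 and 3 in this assay, with no move beyond the scatter in either direction. Compound 4 is thus expected to give about 12%, within a range from 0% to 30%.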

Compound 4, a percentage reported as inhibition, at one concentration (the size of the read-out at that concentration, not a potency): 9.5%
Estimate against measurement, compound 4: 2.5 percentage points above, within the range that was stated.
By their numbers in this assay, from the lowest: compounds 3, 4 and 1 (each within the scatter of the next).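

Putting fluoro in place of acetamido on this aromatic carbon gives, in this assay, a number 7.8 percentage points lower from compound 1 to compound 4 (within the scatter). For the compounds shown here, this is the first comparison at this position that can be read, and it does not separate the two groups, so the reading here does not respond to this swap in any measurable way; the step from amino to fluoro cannot be read, as compound 2 has no number. Nothing in the data shown explains why these readings sit where they do.

As far as these compounds go, it remains open whether a carboxylic acid, a nitrile or a longer chain at this position would move the reading beyond the scatter. Only one concentration is shown, so how these compounds compare in potency also remains open.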